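Pentan-3-yl Sulfone Replacing the Hydroxypyrrolidine Sulfonamide

The source may hold more compounds than are shown below. What is called first, only, known or untested is meant among the compounds shown, and "the series" means these compounds.

Measured so far:
compound 1, `CCN(CC)S(=O)(=O)c1ccc(S(=O)(=O)N2CCC[C@@H](C(=O)N3CCC(F)(F)CC3)C2)cc1`, 120 nM
compound 2, `O=C([C@@H]1CCCN(S(=O)(=O)c2ccc(S(=O)(=O)N3CC[C@@H](O)C3)cc2)C1)N1CCC(F)(F)CC1`, 330 nM

In a functional assay on BXPC-3 cells (Homo sapiens) for inhibition, read by MTT assay, with a stated time of 7 days (on this read-out higher numbers stand for weaker inhibition and lower numbers for stronger inhibition), compound 2 gives the higher of the two numbers; compound 1 sits below it by a 2.8-fold higher number from compound 1 to compound 2 (0.44 log units; beyond the scatter). Compound 3, `CCC(CC)S(=O)(=O)c1ccc(S(=O)(=O)N2CCC[C@@H](C(=O)N3CCC(F)(F)CC3)C2)cc1`, differs from compound 2 by pentan-3-yl in place of 3-hydroxypyrrolidin-1-yl on a sulfonyl sulfur. Among the measured compounds shown here, the only step that bears on this change is the one from compound 1 to compound 2, where the 3-hydroxypyrrolidin-1-yl group brought a modest rise. Pentan-3-yl resembles diethylamino more than it does 3-hydroxypyrrolidin-1-yl, so for compound 3 a modest fall toward compound 1 is expected, a 2.2-fold lower number from compound 2 to compound 3 (0.34 log units; beyond the scatter). Compound 3 is therefore estimated at 150 nM, within 60 nM to 400 nM.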

Compound 3, half-maximal inhibitory concentration: 40 nM
The estimate for compound 3 lay 3.8-fold (0.57 log units) above the measured number; the measured number lies below the stated range.
By their numbers in this assay, from the lowest: compound 3; then compound 1; then compound 2.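

In this assay, pentan-3-yl in place of 3-hydroxypyrrolidin-1-yl on the sulfonyl sulfur gives an 8.3-fold lower number from compound 2 to compound 3 (0.92 log units; beyond the scatter). Pentan-3-yl also improves on diethylamino, with a 3.0-fold lower number from compound 1 to compound 3 (0.48 log units; beyond the scatter), so this all-carbon group without a ring does more than restore the level of the diethylamino sulfonamide, and compound 3 is the strongest of the three. No measured evidence here accounts for this gain. On these data alone, it remains open whether cyclopentyl, tert-butyl or a longer chain such as heptan-4-yl on the same sulfonyl sulfur would lower the number further.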